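The compounds below may be only part of what the source reports. "The series", "measured", "known", "first", "only" and "open" are said of these compounds alone.

Compound 3 `CC(=O)Nc1cccc(NC(=O)COc2ccc3c(=O)ccoc3c2)c1` is one of three analogues that share a core and differ in the amide group attached to the aniline and in the core itself. In an assay on isolated protein for inhibition of Rho-associated protein kinase 2 (Homo sapiens), read by scintillation counting, radiometric assay and 33P incorporation, with a stated time of 40 min, in the presence of a further agent that is not named here (on this read-out higher numbers stand for weaker inhibition and lower numbers for stronger inhibition), compound 3 gives 136 nM, the second highest of the three numbers. Compound 1 `CN(C)c1ccc(C(=O)Nc2cccc(NC(=O)COc3ccc4c(c3)OCCC4=O)c2)cc1` gives 85 nM in this assay, and the two values lie within the scatter of each other, so nothing separates them. Compound 2 `Cc1coc2cc(OCC(=O)Nc3cccc(NC(=O)c4ccc(N(C)C)cc4)c3)ccc2c1=O` gives 2150 nM in this assay, a clearly higher number than compound 3 shows, and the gap between those two values lies beyond the scatter; the two structures differ in more than one place, so the values are all that can be said of the pair.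

Compound 4 `O=C(COc1ccc2c(=O)ccoc2c1)Nc1cccc(NC(=O)c2ccc(Br)cc2)c1` has not yet been measured. Against compound 3 the change is 4-bromophenyl in place of methyl on a carbonyl carbon. Among the compounds with values here, no single-point step between measured compounds tells how this swap behaves on its own. Compound 1 carries an aromatic amide rather than an acetamide and sits at 85 nM, close to compound 3, which gives no sign of a large move in either direction. Compound 4 is therefore expected to land near compound 3, with the step of a 1.4-fold lower number from compound 3 to compound 4 (0.13 log units; within the scatter) estimated to stay within the scatter. The estimate for compound 4 in this assay is 100 nM, with a range from 30 nM to 330 nM.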

Compound 4, half-maximal inhibitory concentration: 49 nM
The estimate for compound 4 lay 2.0-fold (0.31 log units) above the measured number; measured number inside the range.
By their numbers in this assay, from the lowest: compounds 4, 1 and 3 (each within the scatter of the next, the first and the last beyond it); then compound 2.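

In this assay, within the data shown here, the swap of methyl for 4-bromophenyl on a carbonyl carbon gives a 2.8-fold lower number from compound 3 to compound 4 (0.44 log units; beyond the scatter) and so provides the first comparison in this set in which only one place changes. Among these compounds, it shows that this position takes the larger group, with seven heavy atoms and an aromatic ring entering where a single carbon leaves, and that inhibition does not weaken but modestly strengthens, a step that the earlier compounds, which differ from one another in more than one place, could not isolate. No measurement bears on what lies behind this gain, so the step stands as an observation on these two structures alone.

The compounds shown do not separate the part played by the aromatic ring from that of the bromine, a question that a plain phenyl or a 4-chlorophenyl group on the same carbonyl carbon would address. They also leave open how a carboxylic acid or an amine in place of the bromine would read, and whether the same swap carries over to the cores of compound 1 and compound 2.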